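This account rests on a few compounds, and the source may have more. Where it says the series, first, only, none or still open, it means among the compounds named here.

Measured so far:
compound 1, `NC(=O)c1c(NC(=O)Nc2ccc(Cl)cc2)sc2c1CCN(C1CCOCC1)C2` — 2830 nM
compound 2, `CC(C)(C)OC(=O)CCCCCN1CCc2c(sc(NC(=O)Nc3ccc(Cl)cc3)c2C(N)=O)C1` — 620 nM
compound 3, `NC(=O)c1c(NC(=O)Nc2ccc(Cl)cc2)sc2c1CCN(CC1CCCCC1)C2` — 1890 nM

In a functional assay (strain AB) with Danio rerio as the target, read by microscopy, with a stated time of 1 h (on this read-out lower numbers stand for an effect already at smaller amounts and higher numbers for an effect only at larger amounts of compound), compound 3 gives the second highest of the three numbers. Its nearest neighbour is compound 1, and the change a 1.5-fold lower number from compound 1 to compound 3 (0.18 log units; within the scatter) stays within the scatter. The step of a 3.0-fold higher number from compound 2 to compound 3 (0.48 log units; beyond the scatter) is the only one of the three that lies beyond the scatter, and it points to the group on the amine nitrogen in the ring as the place where the numbers move.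

Compound 4, `CC(C)(C)OC(=O)CCCCN1CCc2c(sc(NC(=O)Nc3ccc(Cl)cc3)c2C(N)=O)C1`, is not yet measured. It differs from compound 3 as follows: 3-(tert-butoxycarbonyl)propyl in place of cyclohexyl on a saturated chain carbon bound to an amine nitrogen in a ring. Read one bond further out, cyclohexylmethyl gives way to 4-(tert-butoxycarbonyl)butyl, so compound 4 resembles compound 2 on that nitrogen, with the tert-butoxycarbonyl chain reaching a little less far.

The step of a 3.0-fold higher number from compound 2 to compound 3 (0.48 log units; beyond the scatter) is the measured change that bears on this. Its reverse is what compound 4 should show, and the number for compound 4 is therefore expected to come out lower than for compound 3, roughly by the step of a 2.5-fold lower number from compound 3 to compound 4 (0.40 log units; beyond the scatter). The estimate for compound 4 in this assay is 750 nM, with a range of 300 nM to 1800 nM.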

Compound 4, half-maximal effective concentration: 710 nM
Compound 4: middle estimate off by 1.1-fold (0.02 log units), on the high side; the measured number falls inside the stated range.
By their numbers in this assay, from the lowest: compounds 2 and 4 (each within the scatter of the next); then compounds 3 and 1 (each within the scatter of the next).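

In this assay, the tert-butoxycarbonyl chain on the amine nitrogen in the ring now appears in a second compound, and the shorter 3-(tert-butoxycarbonyl)propyl form gives a 1.1-fold higher number from compound 2 to compound 4 (0.06 log units; within the scatter) and so cannot be told apart from the longer chain of compound 2. Set against the groups that carry a ring, the chain gives a 2.7-fold lower number from compound 3 to compound 4 (0.43 log units; beyond the scatter) and a 4.0-fold lower number from compound 1 to compound 4 (0.60 log units; beyond the scatter) with both steps beyond the scatter, so the gap first seen with compound 2 does not rest on that one compound. Nothing measured here accounts for these differences.

The compounds shown leave open whether the tert-butoxycarbonyl end or the chain alone carries the change. A carboxylic acid or a plain alkyl chain of the same reach would separate the two, and a terminal amine or a still shorter chain would test how far the trend holds.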